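Swapping the methylphenyl arm of compound 1 for fluorophenyl

A few compounds are considered here, and "the series" means these few. Any claim that something is new, unique, unknown or untested is made for them only; others in the source may bear on it.

Within the data shown here, compound 1 `Cc1ccc(Cn2cc(COc3ccc4c(=O)ccoc4c3)nn2)cc1` gives 10400 nM in a functional assay on SW480 cells (Homo sapiens) for cytotoxicity, read by MTT assay, with a stated time of 48 h (on this read-out higher numbers stand for weaker inhibition and lower numbers for stronger inhibition), and is the only compound of this set with a number rather than a limit. Compound 2 `O=c1ccoc2cc(OCc3cn(Cc4cccc(F)c4)nn3)ccc12` reaches only the limit of the assay at > 100000 nM in this assay. Compound 3 `O=c1ccoc2cc(OCc3cn(Cc4cccc([N+](=O)[O-])c4)nn3)ccc12` likewise reaches only the limit at > 100000 nM in this assay. Compound 4 `O=c1ccoc2cc(OCc3cn(Cc4ccccc4F)nn3)ccc12` differs from compound 1 by 2-fluorophenyl in place of 4-methylphenyl on a saturated chain carbon bound to an aromatic nitrogen. The nearest measured steps are an at least 9.6-fold higher number from compound 1 to compound 2 (0.98 log units; beyond the scatter) and an at least 9.6-fold higher number from compound 1 to compound 3 (0.98 log units; beyond the scatter), and both end at the limit of > 100000 nM in this assay, at which 2 of the 3 values shown sit. A weakening step is therefore expected, estimated as a 7.7-fold higher number from compound 1 to compound 4 (0.89 log units; beyond the scatter). Compound 4 is expected to give about 80000 nM in this assay, with a range from 25000 nM to 300000 nM, and may itself stop at the limit.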

Compound 4, half-maximal inhibitory concentration: 11400 nM
Compound 4: middle estimate off by 7.0-fold (0.85 log units), on the high side; measured number outside the range, below it.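

In this assay, replacing 4-methylphenyl with 2-fluorophenyl gives a 1.1-fold higher number from compound 1 to compound 4 (0.04 log units; within the scatter), so a fluorophenyl arm on this carbon can match the methylphenyl arm. The fluorine's place on the ring matters, with 3-fluorophenyl changed to 2-fluorophenyl giving an at least 8.7-fold lower number from compound 2 to compound 4 (0.94 log units; beyond the scatter), and replacing 3-nitrophenyl with 2-fluorophenyl gives an at least 8.7-fold lower number from compound 3 to compound 4 (0.94 log units; beyond the scatter). Both of these steps start from a limit of the assay rather than a number: the limit of > 100000 nM in this assay, at which 2 of the 4 values shown sit.

From the compounds shown here alone, whether a 4-fluorophenyl, 2-chlorophenyl or 2-methoxyphenyl arm would hold this level remains open. So does the effect of an amine or a carboxylic acid on the ring.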